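Amide substituent variation in the series

The source may hold more compounds than are shown below. What is called first, only, known or untested is meant among the compounds shown, and "the series" means these compounds.

Measured so far:
compound 1 `CN(C)C(=O)c1ccncc1Nc1cc(-c2ccc3ccn(C)c3c2)c2nccnc2c1` — > 100000 nM
compound 2 `CN1CCC(NC(=O)c2ccncc2Nc2cc(-c3ccc4ccn(C)c4c3)c3nccnc3c2)CC1` — 19500 nM

In an assay on lysate for inhibition of 6-phosphofructo-2-kinase/fructose-2,6-bisphosphatase 3 (Homo sapiens), with stated times of 0.5 min and 45 min (on this read-out lower numbers stand for stronger inhibition and higher numbers for weaker inhibition), compound 1 gives > 100000 nM, which is a limit of the assay and not a number (the limit of > 100000 nM in this assay, at which 1 of the 2 values shown sits). In this assay compound 2 gives 19500 nM, the only number shown. Within the data shown here, the step of an at least 5.1-fold lower number from compound 1 to compound 2 (0.70 log units; beyond the scatter) is the sole measured step here.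

Compound 3 `Cn1ccc2ccc(-c3cc(Nc4cnccc4C(=O)NC4CCNC(=O)C4)cc4nccnc34)cc21` differs from compound 2 by 2-oxopiperidin-4-yl in place of 1-methylpiperidin-4-yl on an amide-type nitrogen. Among the measured compounds shown here, no measured step covers this change itself; the only step touching the same amide substituent, an at least 5.1-fold lower number from compound 1 to compound 2 (0.70 log units; beyond the scatter), was at least modest. Going from an amine ring to a lactam ring is a different change, so the direction is open. A step within the scatter or a modest one in either direction is expected, a 1.3-fold higher number from compound 2 to compound 3 (0.11 log units; within the scatter). Compound 3 is therefore estimated at 25000 nM, with a range from 6000 nM to 100000 nM.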

Compound 3, half-maximal inhibitory concentration: 56500 nM
Compound 3: the middle estimate sits 2.3-fold (0.35 log units) below what was measured, and the stated range covers the measured number.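

At the amide-type nitrogen, 2-oxopiperidin-4-yl in place of 1-methylpiperidin-4-yl gives a 2.9-fold higher number from compound 2 to compound 3 (0.46 log units; beyond the scatter) in this assay, so this assay separates two six-membered rings of equal heavy-atom count at this place. Against the dimethylamino amide, the reading for the lactam is only an at least 1.7-fold lower number from compound 1 to compound 3 (0.24 log units; that floor lies within the scatter), a floor that does not establish a change. Compound 1 stands at a limit of the assay, not a number: the limit of > 100000 nM in this assay, at which 1 of the 3 values shown sits.

As far as these compounds go, how an unsubstituted piperidin-4-yl, an open-chain aminoalkyl group or a carboxylic acid would read on this amide-type nitrogen remains open. Compound 2 at 19500 nM gives the lowest number shown, and whether any other group at this place goes substantially lower also remains open.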